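A methyl for two chlorines on the benzyl ether

The source may report more compounds than this note shows. Statements on the series, on what has been measured and on what is new or still open speak of the compounds shown alone.

Compound 1 `CC(C)(N)C(=O)N[C@H](COCc1cccc(Cl)c1Cl)c1nnnn1CCOC(=O)NCCCCO`, 0.61 nM; compound 2 `CC(C)(N)C(=O)N[C@H](COCc1ccccc1C(F)(F)F)c1nnnn1CCOC(=O)NCCCCO`, 0.72 nM; compound 3 `CC(C)(N)C(=O)N[C@H](COCc1cc(C(F)(F)F)cc(C(F)(F)F)c1)c1nnnn1CCOC(=O)NCCCCO`, 34 nM; compound 4 `Cc1ccccc1COC[C@@H](NC(=O)C(C)(C)N)c1nnnn1CCOC(=O)NCCCCO`, not yet measured.

In a functional assay on cells for inhibition of growth hormone secretagogue receptor type 1 (Homo sapiens), read by FLIPR and calcium flux (on this read-out lower numbers stand for an effect already at smaller amounts and higher numbers for an effect only at larger amounts of compound), compound 1 stands at the low end of the three numbers; compound 2 with 0.72 nM sits within the scatter of it, while compound 3 with 34 nM lies far higher. The change to compound 4 is 2-methylphenyl in place of 2,3-dichlorophenyl on a saturated chain carbon bound to an oxygen on a saturated carbon. Among the compounds with values here, the one measured step that bears on it, a 1.2-fold higher number from compound 1 to compound 2 (0.07 log units; within the scatter), also exchanged the substituents of this ring and stayed within the scatter. Within the data shown here, compound 3, carrying two trifluoromethyl groups, shows that not every ring pattern is tolerated, but no single-point step to it is given. For compound 4 a small rise is therefore expected: a 2.5-fold higher number from compound 1 to compound 4 (0.39 log units; beyond the scatter). Compound 4 is estimated at 1.5 nM, likely between 0.5 nM and 5 nM.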

Compound 4, half-maximal effective concentration: 0.51 nM
For compound 4 the middle estimate is 2.9-fold (0.47 log units) above the measured one, within the range that was stated.
By their numbers in this assay, from the lowest: compounds 4, 1 and 2 (each within the scatter of the next); then compound 3.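

In this assay, 2-methylphenyl in place of 2,3-dichlorophenyl gives a 1.2-fold lower number from compound 1 to compound 4 (0.08 log units; within the scatter), and methyl in place of trifluoromethyl on an aromatic carbon gives a 1.4-fold lower number from compound 2 to compound 4 (0.15 log units; within the scatter). A single methyl on this ring therefore reads the same as the two chlorines or the single trifluoromethyl, so these three rings cannot be told apart here. Nothing available explains this likeness.

From the compounds shown here alone, compound 3 , at 34 nM, carries two trifluoromethyl groups, and whether their number or their place on the ring matters stays open. Going by these compounds, a ring carrying an amine or a carboxylic acid also remains unknown.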